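The source may hold more compounds than are shown below. What is called first, only, known or untested is meant among the compounds shown, and "the series" means these compounds.

Measured compounds:
compound 1 `Cc1ccc(NC2=CC(=O)c3c(nc4n3[C@H]3OC[C@@H](O)[C@H]3OC4)C2=O)cc1C`, compound 2 `O=C1C(NC2CCCC2)=CC(=O)c2c1nc1n2[C@H]2OC[C@@H](O)[C@H]2OC1`, compound 3 `O=C1C(NC2CCCCC2)=CC(=O)c2c1nc1n2[C@H]2OC[C@@H](O)[C@H]2OC1`.

In a functional assay on HeLa cells (Homo sapiens) for inhibition, read by sulforhodamine B assay (a lower number here means a stronger inhibitor, a higher number a weaker inhibitor), compound 1 gives 4320 nM. Compound 2 reaches only a limit of this assay, > 16000 nM. Compound 3 likewise reaches only a limit, > 16000 nM. So compound 3 stands at the limit, together with compound 2, while compound 1 is the one compound with a number; this rests on (the limit of > 16000 nM in this assay, at which 2 of the 3 values shown sit). The steps of an at least 3.7-fold higher number from compound 1 to compound 2 (0.56 log units; beyond the scatter) and an at least 3.7-fold higher number from compound 1 to compound 3 (0.56 log units; beyond the scatter) both run beyond the scatter, whereas a step that the two limits leave unreadable from compound 2 to compound 3.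

Compound 4 `O=C1C(NCc2ccccc2)=CC(=O)c2c1nc1n2[C@H]2OC[C@@H](O)[C@H]2OC1` differs from compound 3 by benzyl in place of cyclohexyl on an amine nitrogen. This brings an aromatic ring back onto the amine nitrogen, as compound 1 carries, so the step of an at least 1.3-fold lower number from compound 3 to compound 4 (0.12 log units; that floor lies within the scatter) is expected, though its size cannot be read from a limit. Compound 4 is estimated at 12000 nM, within 4000 nM to 40000 nM.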

Compound 4, half-maximal inhibitory concentration: 11000 nM
Beside the measured number, compound 4's estimate is 1.1-fold (0.04 log units) above it; the range from low to high includes it.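

The change to benzyl gives a readable number at this amine nitrogen, with an at least 1.4-fold lower number from compound 3 to compound 4 (0.16 log units; that floor lies within the scatter) and an at least 1.4-fold lower number from compound 2 to compound 4 (0.16 log units; that floor lies within the scatter), and neither step can be sized beyond its floor: the limit of > 16000 nM in this assay, at which 2 of the 4 values shown sit.

An aromatic ring on this nitrogen is still not enough to match compound 1, the step being a 2.5-fold higher number from compound 1 to compound 4 (0.41 log units; beyond the scatter).

The compounds shown leave open how a plain phenyl or a longer chain such as phenethyl on this nitrogen would read. Also open, going by these compounds, is whether the methyl groups of 3,4-dimethylphenyl or the benzyl linkage account for that gap.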